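The source may hold more compounds than are shown below. What is called first, only, known or untested is meant among the compounds shown, and "the series" means these compounds.

Compound 1 `Cc1cc(=O)[nH]c(=O)n1C1C=CC(OC(=O)c2ccccc2)C1`: > 250000 nM
Compound 2 `O=C(OC1C=CC(n2ccc(=O)[nH]c2=O)C1)c1ccccc1`: > 250000 nM

In an ADME assay on CCRF-CEM cells (Homo sapiens) for cytotoxicity, with a stated time of 3 days (a higher number here means that more compound is tolerated, a lower number that less compound is tolerated), compound 2 gives > 250000 nM, which is a limit and not a number. Compound 1 gives > 250000 nM, which is also a limit. Going by the values given here, the only measured step, a step that the two limits leave unreadable from compound 1 to compound 2, therefore offers no size to carry over, and it concerns a different place on the core.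

Compound 3 `O=C(OC1C=CC(n2ccc(=O)n(Cc3cc(F)cc(F)c3)c2=O)C1)c1ccccc1` has 3,5-difluorobenzyl in place of hydrogen on an aromatic nitrogen. Because of the limit of > 250000 nM in this assay, at which 2 of the 2 values shown sit, any readable change in this assay is expected to run towards less compound tolerated, and its size is uncertain. The expected change is an at least 2.0-fold lower number from compound 2 to compound 3 (0.31 log units; beyond the scatter). For compound 3 the estimated value is 120000 nM, with an expected range from 30000 nM to 250000 nM.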

Compound 3, half-maximal cytotoxic concentration: 32000 nM
Estimate against measurement, compound 3: 3.8-fold (0.57 log units) above; the range from low to high includes it.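

In this assay, the aromatic nitrogen of the shared core proves to be a place where a change can be read, which the earlier pair could not show: 3,5-difluorobenzyl in place of hydrogen gives an at least 7.8-fold lower number from compound 2 to compound 3 (0.89 log units; beyond the scatter). Compound 3 is the first compound shown whose value is a number and not a limit. The true step may be larger, because compound 2 stands only at a limit: the limit of > 250000 nM in this assay, at which 2 of the 3 values shown sit.

As far as these compounds go, whether the change comes from the benzyl ring or from its fluorine atoms stays open. So does how a plain benzyl, a methyl or a longer chain on this nitrogen would behave.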